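The compounds below may be only part of what the source reports. "The series", "measured", "known", "first", "only" and "open" are said of these compounds alone.

Three esters of the shared core have been tested so far in a functional assay on WRL68 cells (Homo sapiens) for cytotoxicity, read by MTT assay, with a stated time of 4 h (on this read-out higher numbers stand for weaker inhibition and lower numbers for stronger inhibition), and two of them gave numbers. Compound 1 (`CCC(=O)OC[C@H]1O[C@@H](O[C@@H]2OC=C(C(=O)OC)[C@H]3C[C@H](OC(C)=O)[C@H](C)[C@@H]23)[C@H](OC(C)=O)[C@@H](OC(C)=O)[C@@H]1OC(C)=O`) gives 2.65 ug/mL there. Within the data shown here, compound 2 (`C=CC(=O)OC[C@H]1O[C@@H](O[C@@H]2OC=C(C(=O)OC)[C@H]3C[C@H](OC(C)=O)[C@H](C)[C@@H]23)[C@H](OC(C)=O)[C@@H](OC(C)=O)[C@@H]1OC(C)=O`) comes back as "not active" (no number reported) and so offers no step to work with. Compound 3 (`COC(=O)C1=CO[C@@H](O[C@@H]2O[C@H](COC(=O)C=C(C)C)[C@@H](OC(C)=O)[C@H](OC(C)=O)[C@H]2OC(C)=O)[C@@H]2[C@@H](C)[C@@H](OC(C)=O)C[C@H]12`) gives 1.2 ug/mL and holds the lower of the two numbers available.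

Compound 4 (`COC(=O)C1=CO[C@@H](O[C@@H]2O[C@H](COC(=O)c3cccc([N+](=O)[O-])c3)[C@@H](OC(C)=O)[C@H](OC(C)=O)[C@H]2OC(C)=O)[C@@H]2[C@@H](C)[C@@H](OC(C)=O)C[C@H]12`) alters one group of compound 3 (3-nitrophenyl in place of 2-methylprop-1-en-1-yl on a carbonyl carbon) with 3-nitrophenyl in place of 2-methylprop-1-en-1-yl on a carbonyl carbon. Among the measured compounds shown here, the only measured step at that place is a 2.2-fold lower number from compound 1 to compound 3 (0.34 log units; beyond the scatter) and it is modest, with 2-methylprop-1-en-1-yl in place of ethyl. For the measured compounds named here, no tested compound carries an aromatic group there, so this step is a thin guide. Compound 3 already sits at the low end with 1.2 ug/mL and a step of similar modest size toward a higher number is therefore expected in this assay rather than a further fall. The estimated move is a 2.0-fold higher number from compound 3 to compound 4 (0.30 log units; within the scatter) and it remains uncertain in both directions. Compound 4 is expected at 2.4 ug/mL with 0.7 ug/mL to 8 ug/mL as the estimated range.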

Compound 4, half-maximal inhibitory concentration: 3.2 ug/mL
Compound 4: middle estimate off by 1.3-fold (0.12 log units), on the low side; measured number inside the range.
By their numbers in this assay, from the lowest: compound 3; then compounds 1 and 4 (each within the scatter of the next).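

In this assay, among these compounds, the place on the carbonyl carbon now carries an aromatic group for the first time, and the 3-nitrophenyl group gives a 2.7-fold higher number from compound 3 to compound 4 (0.43 log units; beyond the scatter) in place of 2-methylprop-1-en-1-yl, so compound 3 keeps the lowest number of the series. Against the ethyl group, the same 3-nitrophenyl group gives a 1.2-fold higher number from compound 1 to compound 4 (0.08 log units; within the scatter) and the two cannot be told apart, which shows that this place accepts an aromatic ring without losing a measurable cytotoxic number and that the step toward a lower number seen with 2-methylprop-1-en-1-yl is not carried further by the 3-nitrophenyl group. No measured evidence accounts for this result, so it stands here as a description only.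

The compounds shown do not separate the aromatic ring from the nitro group, and a plain phenyl or a 3-aminophenyl group at the same place would be needed to tell the two apart. A longer chain such as hexyl also lies outside this set, and any step to compound 2 cannot be read, as it has no number.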